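Carboxy in place of hydroxymethyl on the shared core

The source may hold more compounds than are shown below. What is called first, only, known or untested is meant among the compounds shown, and "the series" means these compounds.

Compound 2 `O=C1C=CC2(C=C1)OC(=O)C(c1ccc(CO)cc1)=C2c1ccccc1` holds the lowest of the two numbers measured in an ADME assay on MEpiC cells (Homo sapiens) for antiproliferative activity, read by MTT assay, with a stated time of 48 h; on this read-out lower numbers stand for stronger inhibition and higher numbers for weaker inhibition: compound 2 gives 3860 nM. Among the measured compounds shown here, its only neighbour is compound 1 `O=C1C=CC2(C=C1)OC(=O)C(c1cc3ccccc3s1)=C2c1ccccc1`, which in this assay gives 10800 nM; the step of a 2.8-fold lower number from compound 1 to compound 2 (0.45 log units; beyond the scatter) exchanges one ring substituent for another on a double-bonded ring carbon. Compound 3 `O=C1C=CC2(C=C1)OC(=O)C(c1ccc(C(=O)O)cc1)=C2c1ccccc1` differs from compound 2 in one place: carboxy in place of hydroxymethyl on an aromatic carbon. For the measured compounds named here, the one measured step concerns a different group at a different place on the core and says little about swapping a hydroxymethyl for a carboxy on the six-membered aromatic ring; no measured pair matches this change. The expectation for compound 3 is therefore a 1.3-fold higher number from compound 2 to compound 3 (0.11 log units; within the scatter), that is, nothing beyond the scatter. Compound 3 is estimated at 5000 nM in this assay, with a range from 1500 nM to 16000 nM.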

Compound 3, half-maximal inhibitory concentration: 10400 nM
Compound 3: middle estimate off by 2.1-fold (0.32 log units), on the low side, and the stated range covers the measured number.
By their numbers in this assay, from the lowest: compound 2; then compounds 3 and 1 (each within the scatter of the next).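

In this assay the exchange of hydroxymethyl for carboxy, on an aromatic carbon para to a large group, gives a 2.7-fold higher number from compound 2 to compound 3 (0.43 log units; beyond the scatter) and so shows that the number responds to the group held at this place, which the earlier step, a swap of the whole ring substituent, could not show. With the whole substituent in view, the step of a 1.0-fold lower number from compound 1 to compound 3 (0.02 log units; within the scatter) lies within the scatter, so among these three compounds only 4-(hydroxymethyl)phenyl stands apart, while 4-carboxyphenyl and 1-benzothiophen-2-yl do not separate. Nothing available accounts for this difference.

The compounds shown leave open whether an amine, a methyl ester or a longer chain ending in a hydroxyl at this place would fall with compound 2 or with compound 3. They also leave open whether the same exchange would give a similar step on a core carrying another group in place of its unsubstituted phenyl.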